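Styryl Hydrazone Replaces Bromophenyl in a Cytotoxicity Series

The source may hold more compounds than are shown below. What is called first, only, known or untested is meant among the compounds shown, and "the series" means these compounds.

Three hydrazones built on one shared core have been measured in a functional assay on SW 1116 cells (Homo sapiens) for cytotoxicity, read by MTT assay, with a stated time of 48 h; a higher number here means a weaker inhibitor, a lower number a stronger inhibitor. Compound 1 `O=C(CSc1nnc(-c2ccncc2)o1)N/N=C/c1ccc(Br)cc1` gives 21300 nM, the second highest of the three numbers. Its nearest neighbour is compound 3 `O=C(CSc1nnc(-c2ccncc2)o1)N/N=C/c1ccc(Cl)cc1Cl`, which gives 28900 nM; the step of a 1.4-fold higher number from compound 1 to compound 3 (0.13 log units; within the scatter) lies within the scatter. Furthest from it is compound 2 `O=C(CSc1nnc(-c2ccncc2)o1)N/N=C/c1cc(Cl)ccc1O`, which gives 5240 nM; the step of a 4.1-fold lower number from compound 1 to compound 2 (0.61 log units; beyond the scatter) goes beyond the scatter, as does a 5.5-fold higher number from compound 2 to compound 3 (0.74 log units; beyond the scatter).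

Compound 4 `O=C(CSc1nnc(-c2ccncc2)o1)N/N=C/C=C/c1ccccc1` has not yet been measured. It differs from compound 1 in one place: 2-phenylethenyl in place of 4-bromophenyl on a carbon with a double bond to nitrogen. Going by the values given here, no measured step involves a 2-phenylethenyl group; both steps from compound 1 keep a halogenated phenyl, and only the step to compound 2 moved the number beyond the scatter. The change to compound 4 adds no hydrogen-bond donor or acceptor. A step within the scatter, or at most a modest one in either direction, is expected: a 1.1-fold lower number from compound 1 to compound 4 (0.03 log units; within the scatter). Compound 4 is estimated at 20000 nM, with a range from 7000 nM to 60000 nM.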

Compound 4, half-maximal inhibitory concentration: 14900 nM
For compound 4 the middle estimate is 1.3-fold (0.13 log units) above the measured one, and the stated range covers the measured number.
By their numbers in this assay, from the lowest: compound 2; then compounds 4, 1 and 3 (each within the scatter of the next).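

In this assay, this position on a carbon with a double bond to nitrogen accepts 2-phenylethenyl, a group with no halogen and a double bond outside aromatic rings, without leaving the scatter: a 1.4-fold lower number from compound 1 to compound 4 (0.16 log units; within the scatter) and a 1.9-fold lower number from compound 3 to compound 4 (0.29 log units; within the scatter) both stay within it. Compound 2 remains apart, with a 2.8-fold higher number from compound 2 to compound 4 (0.45 log units; beyond the scatter) as a further step beyond the scatter, so 5-chloro-2-hydroxyphenyl gives the lowest number in the set, and 2-phenylethenyl does not match it. No measurement is available that explains this separation.

A plain phenyl group at this position would show how the number responds to losing the bromine alone, without the added double bond. Also open, as far as these compounds go, is how the number would respond to an amine or a carboxylic acid on the phenyl ring of the 2-phenylethenyl group, or to a longer chain in its place.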